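The source may hold more compounds than are shown below. What is called first, only, known or untested is meant among the compounds shown, and "the series" means these compounds.

Measured compounds:

compound 1 `Cc1ncccc1C#Cc1cc(Cl)ccc1OCC(=O)O` — 143 nM
compound 2 `CC(C)S(=O)(=O)c1ccc(Cl)c(C#Cc2cc(Cl)ccc2OCC(=O)O)c1` — 2.9 nM
compound 3 `CC1(C)C(=O)c2ccc(C#Cc3cc(Cl)ccc3OCC(=O)O)cc2S1(=O)=O` — 31 nM

All three were run in an assay on CHO cells for displacement of a labelled ligand from prostaglandin D2 receptor 2 (Homo sapiens), read by scintillation counting; on this read-out higher numbers stand for weaker inhibition and lower numbers for stronger inhibition. Compound 1 gives 143 nM, the highest of the three numbers. Its nearest neighbour is compound 3 at 31 nM, a gap beyond the scatter; compound 2 at 2.9 nM lies furthest off, also well beyond the scatter. On these figures compound 1 is the weakest binder of the set.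

Compound 4 `O=C(O)COc1ccc(Cl)cc1C#Cc1cccnc1` is not yet measured in this assay. It differs from compound 1 in one place: hydrogen in place of methyl on an aromatic carbon. The change sits on the six-membered aromatic ring with 1 nitrogen, next to the ring nitrogen and ortho to a large group; put the other way, 2-methylpyridin-3-yl becomes pyridin-3-yl.

Within the data shown here, no measured pair shows this particular change, so there is nothing to anchor its size. Taking off a methyl from the weakest compound is expected to leave the number roughly where it is or push it somewhat higher, with the step from compound 1 to compound 4 expected at a 1.5-fold higher number from compound 1 to compound 4 (0.19 log units; within the scatter), around the edge of the scatter. Compound 4 is therefore estimated at 220 nM, within a range of 70 nM to 700 nM.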

Compound 4, inhibition constant: 117 nM
The estimate for compound 4 lay 1.9-fold (0.27 log units) above the measured number; the measured number falls inside the stated range.
By their numbers in this assay, from the lowest: compound 2; then compound 3; then compounds 4 and 1 (each within the scatter of the next).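

In this assay, among these compounds, the change from 2-methylpyridin-3-yl to pyridin-3-yl gives the first single-place step: a 1.2-fold lower number from compound 1 to compound 4 (0.09 log units; within the scatter). On this aromatic carbon, next to the ring nitrogen and ortho to a large group, the methyl can therefore be exchanged for hydrogen without a change that can be read beyond the scatter, so compound 1 and compound 4 cannot be told apart in binding. No supporting data bear on why this exchange leaves binding unresolved.

Still open, going by these compounds, is whether a group larger than methyl on the same carbon, such as ethyl, methoxy or an amine, would also leave the number within the scatter. The compounds shown also do not isolate the ring nitrogen, which could be tested by comparison with a plain phenyl ring.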